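A few compounds are considered here, and "the series" means these few. Any claim that something is new, unique, unknown or untested is made for them only; others in the source may bear on it.

Of the compounds shown here, two carrying the same selenocyanate-bearing core have been measured. Compound 1 `C=CCOC(=O)Nc1ccc([Se]C#N)cc1` gives 5000 nM in an ADME assay on 184B5 cells (Homo sapiens) for cytotoxicity, read by MTT assay, with a stated time of 72 h; on this read-out lower numbers stand for stronger inhibition of growth and higher numbers for weaker inhibition of growth. Compound 2 `N#C[Se]c1ccc(NC(=O)OCc2ccc([N+](=O)[O-])cc2)cc1` gives 6000 nM in this assay, a number within the scatter of compound 1, so the two cannot be told apart. Compound 3 `N#C[Se]c1ccc(NC(=O)OCc2ccccc2)cc1` is compound 2 with hydrogen in place of nitro on an aromatic carbon. Going by the values given here, no measured pair shows what this change does, so no step beyond the scatter is expected; the expected shift a 1.2-fold lower number from compound 2 to compound 3 (0.08 log units; within the scatter) is small. Compound 3 is therefore estimated at 5000 nM, with a likely range from 2000 nM to 12000 nM.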

Compound 3, concentration for 50% growth inhibition: 5000 nM
For compound 3 middle estimate and measured number coincide at the digits printed; the measured number falls inside the stated range.
By their numbers in this assay, from the lowest: compounds 1, 3 and 2 (each within the scatter of the next).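

In this assay hydrogen in place of nitro on an aromatic carbon gives a 1.2-fold lower number from compound 2 to compound 3 (0.08 log units; within the scatter) and so the nitro group is not needed for a number in this range. Phenyl in place of vinyl on a saturated chain carbon bound to an oxygen next to a carbonyl group gives no change at the digits printed from compound 1 to compound 3 (within the scatter) and so these two groups cannot be told apart here. Nothing available explains either result. As far as these compounds go, whether an amine or a carboxylic acid on that aromatic carbon would shift the number stays open. So does the effect of a longer chain in place of the vinyl.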